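This account rests on a few compounds, and the source may have more. Where it says the series, first, only, none or still open, it means among the compounds named here.

Compounds measured in an assay on Cerebral cortex for displacement of a labelled ligand from adenosine receptor A1 (Bos taurus); on this read-out lower numbers stand for stronger inhibition and higher numbers for weaker inhibition:
- compound 1 `c1ccc(Cn2nnc3c(NC4CCCC4)nc(-c4ccccc4)nc32)cc1`: 11 nM
- compound 2 `Clc1ccccc1Cn1nnc2c(NC3CCCC3)nc(-c3ccccc3)nc21`: 9 nM

Within this pair compound 2 carries the lower number, and the step of a 1.2-fold lower number from compound 1 to compound 2 (0.09 log units; within the scatter) is within the scatter, so the two compounds are not separable on this read-out.

Compound 3 `OCCCNc1nc(-c2ccccc2)nc2c1nnn2Cc1ccccc1Cl` is the next compound in the series, not yet measured in this assay. It differs from compound 2 in one place: 3-hydroxypropyl in place of cyclopentyl on a nitrogen on an aromatic ring. For the measured compounds named here, neither measured step bears on this change; the only step in hand, chloro in place of hydrogen on an aromatic carbon, touches a different part of the molecule and was itself within the scatter. Going by the values given here, the exchange of cyclopentylamino for (3-hydroxypropyl)amino therefore has no precedent in this set, and the expectation rests on the size and kind of the change alone: a ring gives way to an open chain that brings a hydrogen-bond donor and acceptor. A clear move toward a higher number is expected, of the order a 17-fold higher number from compound 2 to compound 3 (1.22 log units; beyond the scatter). The estimate for compound 3 in this assay is 150 nM, with a range from 30 nM to 800 nM.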

Compound 3, inhibition constant: 33 nM
Estimate against measurement, compound 3: 4.5-fold (0.66 log units) above, within the range that was stated.
By their numbers in this assay, from the lowest: compounds 2 and 1 (each within the scatter of the next); then compound 3.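

Working notes on the nitrogen substituent: in this assay, the change from cyclopentyl to 3-hydroxypropyl on a nitrogen on an aromatic ring gives the first step in the series that lies beyond the scatter (a 3.7-fold higher number from compound 2 to compound 3 (0.56 log units; beyond the scatter)), while the chloro exchange elsewhere on the molecule stayed within it (a 1.2-fold lower number from compound 1 to compound 2 (0.09 log units; within the scatter)). The step is modest, so at this position the ring of compound 2 can give way to an open chain carrying a hydroxyl and the number in this read-out rises only moderately. Nothing in hand gives a measured reason for the shift, so it stands as an observation only.

For the compounds shown here, the single step replaces the ring with an open chain and introduces the hydroxyl at the same time, so the share of each remains unresolved; a plain propyl chain and a hydroxycyclopentyl group would separate the two. Also open, as far as these compounds go, is whether a longer chain, or an amine or a carboxylic acid in place of the hydroxyl, would move the number further, and whether the step holds on compound 1, which lacks the chloro group.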